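The source may hold more compounds than are shown below. What is called first, only, known or untested is meant among the compounds shown, and "the series" means these compounds.

Compound 3 (`CCC(=O)c1ccc(NCc2cncn2Cc2ccc(-c3ccccc3)cc2)cc1-c1ccccc1`) shares its core with compound 1 (`O=C(c1ccc(NCc2cncn2Cc2ccc(-c3ccccc3)cc2)cc1-c1ccccc1)N1CCCCC1`) and compound 2 (`CNC(=O)c1ccc(NCc2cncn2Cc2ccc(-c3ccccc3)cc2)cc1-c1ccccc1`). In a toxicity assay on NIH3T3 cells (Mus musculus) for cytotoxicity, read by resazurin assay (on this read-out lower numbers stand for an effect already at smaller amounts and higher numbers for an effect only at larger amounts of compound), compound 3 gives > 10000 nM as a limit of the assay, not as a number. Compound 1 gives > 1000 nM as a limit too. Compound 2 gives > 1000 nM as a limit too. Compound 3 therefore has no exact place on the scale, and the series offers only two limits (the limit of > 1000 nM in this assay, at which 2 of the 3 values shown sit) (the limit of > 10000 nM in this assay, at which 1 of the 3 values shown sits).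

Compound 4 (`c1ccc(-c2ccc(Cn3cncc3CNc3ccc(-c4cncs4)c(-c4ccccc4)c3)cc2)cc1`) has 1,3-thiazol-5-yl in place of propanoyl on an aromatic carbon. Three measured steps come closest, all changing the group on a carbonyl carbon: (a step that the two limits leave unreadable from compound 1 to compound 2), (a step that the two limits leave unreadable from compound 1 to compound 3) and (a step that the two limits leave unreadable from compound 2 to compound 3). None of them has a readable size, and none removes the carbonyl, so they provide no measured size to carry over to the new change.

The closest guide is compound 3, with > 10000 nM as its limit. In this assay the expected step is (an at least 1.2-fold lower number from compound 3 to compound 4 (0.09 log units; that floor lies within the scatter)), which would be a modest move toward lower numbers, if any move appears. For compound 4 the estimated value is 8000 nM with an expected range from 2000 nM to 20000 nM in this estimate. The result may well turn out to be another limit.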

Compound 4, half-maximal effective concentration: > 1000 nM
Compound 4 gave a limit, no number (the forecaster's own chance of this, stated with the estimate: 65%); the middle value lies beyond the limit too.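

In this assay compound 4 gives > 1000 nM, a limit of the assay and not a number. For the compounds shown here, compound 1, compound 2 and compound 3 also have only limits, so no step to compound 4 can be read. The compounds shown leave open where each sits on the scale and whether 1,3-thiazol-5-yl in place of propanoyl changes the read-out at all.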